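Ring-nitrogen substituent change in the shared core series

A few compounds are considered here, and "the series" means these few. Any claim that something is new, unique, unknown or untested is made for them only; others in the source may bear on it.

Of the compounds shown here, three of the shared core have been measured in an assay on CHO cells for displacement of a labelled ligand from adenosine receptor A1 (Homo sapiens), read by scintillation counting, with a stated time of 120 min, tested at 10 uM; a lower number here means less inhibition, a higher number more inhibition at the concentration tested (going by the name of the read-out). Compound 1 `Nc1scc(CN2CCN(c3cccc(Cl)c3Cl)CC2)c1C(=O)c1ccc(Cl)cc1` gives 2%. Compound 2 `Nc1scc(CN2CCN(c3ccc(OC(F)(F)F)cc3)CC2)c1C(=O)c1ccc(Cl)cc1` gives 0%, and compound 3 `Nc1scc(CN2CCN(c3ccc(F)c(Cl)c3)CC2)c1C(=O)c1ccc(Cl)cc1` gives 0%. The steps between them are all small: a number 2 percentage points lower from compound 1 to compound 2 (within the scatter), a number 2 percentage points lower from compound 1 to compound 3 (within the scatter) and no change at the digits printed from compound 2 to compound 3 (within the scatter). Compound 3 therefore stands level with compound 2 at the digits shown, the two together being the lowest of the three numbers, while compound 1 is the furthest from compound 3 and still within the scatter. All three sit at the floor of the read-out.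

The next compound is compound 4 `Nc1scc(CN2CCN(CCCc3ccc(Cl)cc3)CC2)c1C(=O)c1ccc(Cl)cc1`. The change from compound 3 is 3-(4-chlorophenyl)propyl in place of 3-chloro-4-fluorophenyl on an amine nitrogen in a ring. None of the three measured steps bears directly on this change: each of them swaps one aromatic group for another on the amine nitrogen in the ring, whereas here the aromatic group gives way to a chain carrying an aromatic group. The only guidance is that every variant so far has shown essentially no inhibition, so the expected step in this assay is none beyond the scatter, a number 3 percentage points higher from compound 3 to compound 4 (within the scatter). Compound 4 is estimated at 3%, with a range from -8% to 15%.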

Compound 4, a percentage reported as inhibition, at one concentration (the size of the read-out at that concentration, not a potency): 0%
The estimate for compound 4 lay 3 percentage points above the measured number; the measured number falls inside the stated range.
By their numbers in this assay, from the lowest: compounds 2, 3, 4 and 1 (each within the scatter of the next).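

In this assay, 3-(4-chlorophenyl)propyl in place of 3-chloro-4-fluorophenyl gives no change at the digits printed from compound 3 to compound 4 (within the scatter), the same group in place of 4-(trifluoromethoxy)phenyl gives no change at the digits printed from compound 2 to compound 4 (within the scatter), and in place of 2,3-dichlorophenyl it gives a number 2 percentage points lower from compound 1 to compound 4 (within the scatter). The earlier compounds only exchanged one substituted phenyl group for another on the amine nitrogen in the ring, whereas compound 4 carries a chain bearing the aromatic ring, with 10 heavy atoms entering where 8 leave, and the number stays at the floor of the read-out, so across these four compounds this position has shown no step beyond the scatter, and none of them goes against that. No separate measurement is available that bears on this result.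

Going by these compounds, whether a group with no aromatic ring on this nitrogen, such as a cyclohexyl group or a simple acyl group, would lift the number off the floor remains open. Also open, on these data alone, is whether a longer chain, or a chain ending in an amine or a carboxylic acid, would behave any differently from 3-(4-chlorophenyl)propyl on the shared core.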